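Moving the Ring Nitrogen Within the Urea Aryl Group

This account rests on a few compounds, and the source may have more. Where it says the series, first, only, none or still open, it means among the compounds named here.

Going by the values given here, compound 2 `CN(C)C1(Cc2ccccc2)CCN(c2cc(C(F)(F)F)ccc2CNC(=O)Nc2ccc3cccnc3c2)CC1` gives 14.1 nM in an assay on CHO cells for displacement of a labelled ligand from transient receptor potential cation channel subfamily V member 1 (Homo sapiens), read by scintillation counting, with a stated time of 60 min (on this read-out lower numbers stand for stronger inhibition and higher numbers for weaker inhibition), the lower of the two numbers so far available. Among the compounds with values here, its only measured neighbour is compound 1 `CN(C)C1(Cc2ccccc2)CCN(c2cc(C(F)(F)F)ccc2CNC(=O)Nc2ccc(NS(C)(=O)=O)c(F)c2)CC1`, which in this assay gives 1160 nM; the step of an 82-fold lower number from compound 1 to compound 2 (1.92 log units; beyond the scatter) is the sole measured step and concerns a different replacement on the amide-type nitrogen. Compound 3 `CN(C)C1(Cc2ccccc2)CCN(c2cc(C(F)(F)F)ccc2CNC(=O)Nc2ccc3ccncc3c2)CC1` differs from compound 2 in one place: isoquinolin-7-yl in place of quinolin-7-yl on an amide-type nitrogen. Within the data shown here, no measured step bears on this change directly; the step from compound 1 to compound 2 shows only that the group on the amide-type nitrogen matters greatly, not how these two groups compare with each other. With nothing to anchor the direction, the expected step of a 2.1-fold higher number from compound 2 to compound 3 (0.33 log units; beyond the scatter) in this assay is small, most likely within the scatter or slightly weaker. Compound 3 is therefore estimated at 30 nM, within a range of 8 nM to 120 nM.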

Compound 3, inhibition constant: 7.33 nM
Estimate against measurement, compound 3: 4.1-fold (0.61 log units) above; measured number outside the range, below it.
By their numbers in this assay, from the lowest: compounds 3 and 2 (each within the scatter of the next); then compound 1.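

In this assay, the step of a 1.9-fold lower number from compound 2 to compound 3 (0.28 log units; within the scatter) shows that at this place on the amide-type nitrogen, quinolin-7-yl and isoquinolin-7-yl, which have the same atoms joined differently, cannot be told apart. The large step of a 160-fold lower number from compound 1 to compound 3 (2.20 log units; beyond the scatter) stands with an 82-fold lower number from compound 1 to compound 2 (1.92 log units; beyond the scatter) as a second such step away from 3-fluoro-4-(methanesulfonamido)phenyl, so the lower number does not depend on which of these two ring arrangements is present. No supporting measurement is available to explain why the two groups read alike.

As far as these compounds go, whether the ring nitrogen is needed at all remains open, and a naphthyl group, with carbon only in both rings, would address that. A quinazolinyl group, with a second ring nitrogen, would show whether adding nitrogen to this ring changes the number.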